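The compounds below may be only part of what the source reports. "The series", "measured", "known", "first", "only" and "open" are said of these compounds alone.

Compound 1 `CCc1ccc(C(=O)/C=C/c2ccc3c(c2)B(O)OC3)cc1`: > 10 ug/mL
Compound 2 `O=C(/C=C/c1ccc2c(c1)B(O)OC2)c1ccccc1O`: > 10 ug/mL
Compound 3 `COc1cccc(C(=O)CCc2ccc3c(c2)B(O)OC3)c1`: > 10 ug/mL

These results come from an ADME assay on L929 cells (Mus musculus) for cytotoxicity, read by resazurin assay, with a stated time of 72 h; on this read-out higher numbers stand for weaker inhibition and lower numbers for stronger inhibition. Compound 2 stands at > 10 ug/mL, which is a limit of the assay and not a number. The other two compounds give no sharper picture, as the record reads (the limit of > 10 ug/mL in this assay, at which 3 of the 3 values shown sit).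

Compound 4 `O=C(/C=C/c1ccc2c(c1)B(O)OC2)c1ccccc1F` differs from compound 2 in one place: fluoro in place of hydroxy on an aromatic carbon. In words, 2-hydroxyphenyl becomes 2-fluorophenyl. Within the data shown here, no measured pair shows what this swap does in this assay, so the expectation is no step beyond the usual scatter, in either direction. The expected change, a number no higher from compound 2 to compound 4 (the limit leaves the size open), is therefore small. For compound 4 the estimated value is 10 ug/mL, with an expected range from 5 ug/mL to 20 ug/mL.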

Compound 4, half-maximal inhibitory concentration: > 10 ug/mL
Compound 4: a limit, no number (the forecaster's own chance of this, stated with the estimate: 75%); the middle value lies on the limit itself.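

Compound 2 and compound 4 both sit at a limit of the assay, so no step can be read between them: the limit of > 10 ug/mL in this assay, at which 4 of the 4 values shown sit. Whether fluoro in place of hydroxy changes anything in this assay stays open, as does the true value of every compound shown.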